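This account rests on a few compounds, and the source may have more. Where it says the series, first, only, none or still open, it means among the compounds named here.

Compounds measured in a functional assay on CCRF-CEM cells (Homo sapiens), read by MTT assay, with a stated time of 72 h; on this read-out lower numbers stand for stronger inhibition and higher numbers for weaker inhibition:
- compound 1 `COc1ncnc2c1c(-c1ccccc1)cn2[C@@H]1O[C@H](CO)[C@@H](O)[C@H]1O`: > 20000 nM (a limit)
- compound 2 `CNc1ncnc2c1c(-c1ccco1)cn2[C@@H]1O[C@H](CO)[C@@H](O)[C@H]1O`: 180 nM
- compound 3 `CNc1ncnc2c1c(-c1ccsc1)cn2[C@@H]1O[C@H](CO)[C@@H](O)[C@H]1O`: > 20000 nM (a limit)

Compound 3 gives no true number, only a limit of the assay: > 20000 nM. It therefore stands at the limit of > 20000 nM in this assay, at which 2 of the 3 values shown sit. Compound 1 is the other one at that limit, and only compound 2 gives a true number.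

Compound 4 `CNc1ncnc2c1c(-c1ccccc1)cn2[C@@H]1O[C@H](CO)[C@@H](O)[C@H]1O` has not yet been measured. It has phenyl in place of thiophen-3-yl on an aromatic carbon of the shared core: phenyl in place of thiophen-3-yl on an aromatic carbon.

Going by the values given here, one measured step bears on this place: an at least 110-fold higher number from compound 2 to compound 3 (2.04 log units; beyond the scatter). Among the compounds with values here, it shows that the group there can matter greatly, but it starts from furan-2-yl, and no measured step leads from thiophen-3-yl to phenyl. Compound 4 differs elsewhere from compound 1, which also carries phenyl at this place. The value of compound 1 is the limit > 20000 nM. On that basis, no step beyond the scatter is expected in this assay, so a reading at or near the limit seems likely.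

The expected step is a number no higher from compound 3 to compound 4 (the limit leaves the size open).

For compound 4 the estimated value is 20000 nM, with an expected range from 5000 nM to 40000 nM.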

Compound 4, half-maximal inhibitory concentration: > 20000 nM
Compound 4 ended at the assay's limit (the forecaster's own chance of this, stated with the estimate: 70%); the middle value lies on the limit itself.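

In this assay, phenyl joins thiophen-3-yl as a second replacement for furan-2-yl at this place on the shared core. Exchanging furan-2-yl for phenyl gives an at least 110-fold higher number from compound 2 to compound 4 (2.04 log units; beyond the scatter), so with methylamino held constant, neither of the two replacements shown keeps the true number seen with furan-2-yl. Compound 4 also shows that methylamino in place of the methoxy of compound 1 does not bring phenyl off the limit, while the steps from compound 3 to compound 4 and from compound 1 to compound 4 cannot be read, as both compounds of each pair sit at the same limit and nothing ranks these groups against one another: the limit of > 20000 nM in this assay, at which 3 of the 4 values shown sit.

Going by these compounds alone, compound 2 remains the only compound here with a true number, so it is open whether a group closer to furan-2-yl, such as thiophen-2-yl, or a small one, such as methyl or chlorine, would keep a measurable value at this place. On these data alone, it is also open whether furan-2-yl would hold its value with methoxy in place of methylamino, or with an amine carrying a longer chain.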